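The compounds below may be only part of what the source reports. "The series", "measured", "known", "first", "only" and "open" are said of these compounds alone.

In an assay on HEK293 cells for positive allosteric modulation of metabotropic glutamate receptor 2 (Rattus norvegicus), read by thallium flux, with a stated time of 2.5 min (on this read-out lower numbers stand for an effect already at smaller amounts and higher numbers for an effect only at larger amounts of compound), compound 2 `Cc1c(OCCCCOCOc2ccc(C(=O)O)cc2)ccc(C(=O)CC2CCCC2)c1O` gives 228 nM, the highest of the three numbers recorded so far. Compound 3 `Cc1c(OCCCCOc2ccc(F)c(C(=O)O)c2)ccc(C(=O)CC(C)(C)C)c1O` gives 208 nM, which sits within the scatter of compound 2, so the two cannot be told apart. Compound 1 `COc1cc(C(=O)O)ccc1OCCCCOc1ccc(C(=O)CC(C)(C)C)c(O)c1C` gives 47 nM, a gap to compound 2 that lies beyond the scatter. Compound 4 `Cc1c(OCCCCOc2cccc(C(=O)O)c2)ccc(C(=O)CC2CCCC2)c1O` has not yet been measured in this assay. It differs from compound 2 in one place: 3-carboxyphenyl in place of (4-carboxyphenoxy)methyl on an oxygen on a saturated carbon. Neither compound 1 nor compound 3 carries the (4-carboxyphenoxy)methyl piece, and both give numbers that are not above compound 2. A modest step toward smaller amounts is therefore expected, so that a 1.6-fold lower number from compound 2 to compound 4 (0.21 log units; within the scatter). Compound 4 is estimated at 140 nM, with a range from 55 nM to 380 nM.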

Compound 4, half-maximal effective concentration: 451 nM
Compound 4: middle estimate off by 3.2-fold (0.51 log units), on the low side; the whole stated range lies below it.
By their numbers in this assay, from the lowest: compound 1; then compounds 3, 2 and 4 (each within the scatter of the next, the first and the last beyond it).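

a 2.0-fold higher number from compound 2 to compound 4 (0.30 log units; within the scatter) in this assay, so 3-carboxyphenyl and (4-carboxyphenoxy)methyl cannot be told apart on this oxygen. Among the compounds shown here, this is the first pair here that differs in one place, and it shows that this swap, which keeps a carboxyphenyl-type group but changes how it is attached, leaves no readable difference at this position. Nothing available here bears on the reason for this result. Still open, from the compounds shown here alone, is whether a plain phenyl, with no carboxylic acid, or a tetrazole in place of that acid would give a similar number.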